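A few compounds are considered here, and "the series" means these few. Any claim that something is new, unique, unknown or untested is made for them only; others in the source may bear on it.

Compounds measured so far:
compound 1 `COc1ccc(-c2nc3c(NC4CCCC4)ncnc3n2C)cc1` — 1850 nM
compound 2 `Cc1ccc(-c2nc3c(NC4CCCC4)ncnc3n2C)cc1` — 480 nM
compound 3 `Cn1c(-c2ccccc2)nc2c(NC3CCOC3)ncnc21` — 6260 nM

In an assay on CHO cells for displacement of a labelled ligand from adenosine receptor A3 (Homo sapiens), read by scintillation counting, with a stated time of 3 h (a higher number here means a weaker inhibitor, a lower number a stronger inhibitor), compound 3 gives the highest number of the three, with compound 1 nearest and compound 2 furthest away. Compound 4 `Cn1c(-c2ccccc2)nc2c(NC3CCCC3)ncnc21` differs from compound 3 by cyclopentyl in place of oxolan-3-yl on a nitrogen on an aromatic ring. Going by the values given here, the only measured step, a 3.9-fold lower number from compound 1 to compound 2 (0.59 log units; beyond the scatter), concerns the substituent on the aromatic ring and not the group on the amine nitrogen, so no measured step bears directly on this change. Compounds 1 and 2, which both carry cyclopentylamino, give lower numbers in this assay than compound 3, though they also differ on the aromatic ring. Compound 4 is therefore expected to show a step of a 4.2-fold lower number from compound 3 to compound 4 (0.62 log units; beyond the scatter), and its value in this assay is estimated at 1500 nM, within a range of 500 nM to 4500 nM.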

Compound 4, inhibition constant: 846 nM
Compound 4: the middle estimate sits 1.8-fold (0.25 log units) above what was measured; measured number inside the range.
By their numbers in this assay, from the lowest: compounds 2 and 4 (each within the scatter of the next); then compound 1; then compound 3.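

In this assay, cyclopentyl in place of oxolan-3-yl on the same core gives a 7.4-fold lower number from compound 3 to compound 4 (0.87 log units; beyond the scatter), so this change now has a step of its own, free of any second difference. On the aromatic carbon, hydrogen in place of methyl gives a 1.8-fold higher number from compound 2 to compound 4 (0.25 log units; within the scatter), whereas hydrogen in place of methoxy gives a 2.2-fold lower number from compound 1 to compound 4 (0.34 log units; beyond the scatter). Nothing available explains these steps.

The compounds shown leave open how a cyclohexyl ring, a piperidine or an open butyl chain on the amine nitrogen would compare with cyclopentyl. They also leave open whether a chlorine or a hydroxyl on the aromatic carbon would follow methyl or methoxy.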